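The compounds below may be only part of what the source reports. "The series", "measured", "known", "first", "only" and "open" are said of these compounds alone.

Compounds measured so far:

- compound 1 `CCCCCOC(=O)N1CCN(C(=O)[C@H](CCC(=O)O)NC(=O)c2nc(-c3ccccc3)cc(N3CCC(COC)CC3)n2)CC1`: 6 mL/min/kg
- compound 2 `CCCCCOC(=O)N1CCN(C(=O)[C@H](CCC(=O)O)NC(=O)c2cc(N3CCC(C(=O)N4CCCC4)CC3)nc(-c3ccccc3)n2)CC1`: 2 mL/min/kg
- compound 3 `CCCCCOC(=O)N1CCN(C(=O)[C@H](CCC(=O)O)NC(=O)c2cc(N3CCC(OCCO)CC3)nc(-c3ccccc3)n2)CC1`: 18 mL/min/kg

In an in vivo ADME assay on the whole organism (strain Sprague-Dawley) for pharmacokinetics, with Rattus norvegicus as the target (a higher number here means faster removal of the compound, a lower number slower removal), compound 3 gives the highest of the three numbers; compound 1 sits nearest to it, and compound 2 lies furthest away. The step to be followed leads from compound 3 to compound 4 `CCCCCOC(=O)N1CCN(C(=O)[C@H](CCC(=O)O)NC(=O)c2cc(N3CCC(C(N)=O)CC3)nc(-c3ccccc3)n2)CC1`, where the structures differ in one place: carbamoyl in place of 2-hydroxyethoxy on a saturated ring carbon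

Among the compounds with values here, only one measured step bears directly on this change. It is a 9.0-fold higher number from compound 2 to compound 3 (0.95 log units; beyond the scatter), in which an amide built on the same saturated ring carbon was exchanged for the 2-hydroxyethoxy group. Compound 4 carries a carbamoyl group, which is again an amide on that carbon, so the change from compound 3 to compound 4 runs back in the direction of compound 2. A drop beyond the scatter is therefore expected in this assay, though the carbamoyl group is not identical to the group in compound 2, so the full return to that number is not assumed.

The estimate for compound 4 in this assay is 5 mL/min/kg, with a range from 2 mL/min/kg to 12 mL/min/kg, and the expected step is a 3.6-fold lower number from compound 3 to compound 4 (0.56 log units; beyond the scatter).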

Compound 4, clearance: 68 mL/min/kg
Beside the measured number, compound 4's estimate is 14-fold (1.13 log units) below it; the whole stated range lies below it.
By their numbers in this assay, from the lowest: compound 2; then compound 1; then compound 3; then compound 4.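

In this assay an amide on this saturated ring carbon does not by itself bring a low number: the change gives a 3.8-fold higher number from compound 3 to compound 4 (0.58 log units; beyond the scatter) and so runs upward from the 2-hydroxyethoxy compound. The two amides differ only in what sits on the carbonyl carbon, and amino in place of pyrrolidin-1-yl gives a 34-fold higher number from compound 2 to compound 4 (1.53 log units; beyond the scatter), so among these compounds the substitution of the amide counts for more than the presence of an amide. No measurement shown explains why the two amides part so widely.

On these data alone, it remains open how an amide carrying a single methyl group on its nitrogen would compare with these two amides. A carboxylic acid or an amine on the same ring carbon is also untested among the compounds shown.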